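Phenyl substituent swaps on a shared core

This account rests on a few compounds, and the source may have more. Where it says the series, first, only, none or still open, it means among the compounds named here.

Measured so far:
compound 1 `COc1ccc(-c2cc3cc(C)ccc3c(-c3cccc(O)c3)n2)cc1OC` gives 6510 nM in a functional assay on DU-145 cells (Homo sapiens) for cytotoxicity, read by CCK-8 assay and cell counting, with a stated time of 72 h; a lower number here means a stronger inhibitor, a higher number a weaker inhibitor
compound 2 `COc1ccc(-c2cc3cc(C)ccc3c(-c3cccc(N)c3)n2)cc1OC` gives 4190 nM in this assay

Among the compounds with values here, compound 2 sits at the lower end of the two numbers; the only measured step, a 1.6-fold lower number from compound 1 to compound 2 (0.19 log units; within the scatter), lies within the scatter, so the two compounds are not distinguished. Compound 3 `COc1ccc(-c2cc3cc(C)ccc3c(-c3ccc(O)cc3)n2)cc1OC` differs from compound 2 by 4-hydroxyphenyl in place of 3-aminophenyl on an aromatic carbon. Within the data shown here, the one step that bears on it, the hydroxy-for-amino exchange, was within the scatter; no measured step covers the shift from 3-aminophenyl to 4-hydroxyphenyl. With nothing beyond the scatter in hand, the expected step in this assay is a 1.2-fold higher number from compound 2 to compound 3 (0.08 log units; within the scatter), no direction beyond the scatter. Compound 3 is therefore estimated at 5000 nM, with a range of 1800 nM to 14000 nM.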

Compound 3, half-maximal inhibitory concentration: 5980 nM
The estimate for compound 3 lay 1.2-fold (0.08 log units) below the measured number, within the range that was stated.
By their numbers in this assay, from the lowest: compounds 2, 3 and 1 (each within the scatter of the next).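

In this assay, moving the hydroxy group from 3-hydroxyphenyl to 4-hydroxyphenyl gives a 1.1-fold lower number from compound 1 to compound 3 (0.04 log units; within the scatter) and so does not separate the two placements. Exchanging 3-aminophenyl for 4-hydroxyphenyl gives a 1.4-fold higher number from compound 2 to compound 3 (0.15 log units; within the scatter) and likewise separates nothing, so compounds 1, 2 and 3 all remain within the scatter of one another at this position. No other data bear on this result.

Still open, from the compounds shown here alone, is how an unsubstituted phenyl, a 4-aminophenyl or a carboxylic acid on this ring would compare. A step beyond the scatter at this position is also yet to be seen.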